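The compounds below may be only part of what the source reports. "The series", "measured", "known", "first", "only" and "open" are said of these compounds alone.

In a functional assay on LOX IMVI cells (Homo sapiens) for inhibition, read by sulforhodamine B assay, with a stated time of 48 h (a higher number here means that more compound is tolerated, a lower number that less compound is tolerated), two compounds have been measured so far. Compound 1 `O=C(Nc1cccc(-n2cc(-c3ccncc3)c(-c3ccc(Cl)c(O)c3)n2)c1)Nc1cccc(C(F)(F)F)c1` gives 32400 nM. Compound 2 `COc1cc(-c2nn(-c3cccc(NC(=O)Nc4cc(C(F)(F)F)cc(C(F)(F)F)c4)c3)cc2-c2ccncc2)ccc1Cl` gives 2940 nM, the lowest of the two numbers; the gap to compound 1 lies beyond the usual scatter, so compound 2 is the one of which less is tolerated. The two compounds differ at more than one place, so their values alone show no single cause.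

Compound 3 `O=C(Nc1cccc(-n2cc(-c3ccncc3)c(-c3ccc(Cl)c(O)c3)n2)c1)Nc1cc(C(F)(F)F)cc(C(F)(F)F)c1` has not yet been measured. It differs from compound 2 by hydrogen in place of methyl on an oxygen on an aromatic ring. For the measured compounds named here, compound 3 shares this hydroxy form with compound 1, while it keeps the two trifluoromethyl groups of compound 2, and no measured pair isolates this change. A modest move upward, toward more compound being tolerated, is the expectation here, with a real chance of no change beyond the scatter. Compound 3 is therefore expected to give about 6000 nM, with a range from 2000 nM to 20000 nM, meaning an estimated step of a 2.0-fold higher number from compound 2 to compound 3 (0.31 log units; beyond the scatter) in this assay.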

Compound 3, concentration lethal to 50% of the cells: 2750 nM
Beside the measured number, compound 3's estimate is 2.2-fold (0.34 log units) above it; the measured number falls inside the stated range.
By their numbers in this assay, from the lowest: compounds 3 and 2 (each within the scatter of the next); then compound 1.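

In this assay, exchanging methoxy for hydroxy on the 4-chloro-3-methoxyphenyl group gives a 1.1-fold lower number from compound 2 to compound 3 (0.03 log units; within the scatter), so this position on the oxygen shows no measurable difference between methyl and hydrogen in the context of two trifluoromethyl groups. The other new step separates what the first two compounds left tangled: adding trifluoromethyl in place of hydrogen on an aromatic carbon, with the hydroxy group unchanged, gives a 12-fold lower number from compound 1 to compound 3 (1.07 log units; beyond the scatter), a large step, so the wide gap seen earlier goes with the second trifluoromethyl group and not with the methyl on the oxygen. No information is available on why either step comes out as it does.

The compounds shown leave open whether methoxy and hydroxy would also read alike with a single trifluoromethyl group, since only the hydroxy form appears in that setting. They also leave open how a longer chain such as ethoxy, or an amine in place of the hydroxy, would read at the oxygen position, and whether a nitrile or a chlorine could stand in for the second trifluoromethyl group.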